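This account rests on a few compounds, and the source may have more. Where it says the series, first, only, none or still open, it means among the compounds named here.

In a functional assay on cells (Cancer cell lines, Homo sapiens) for inhibition (on this read-out lower numbers stand for stronger inhibition of growth and higher numbers for weaker inhibition of growth), compound 1 (`Nc1ccc(-c2nc3ccc(F)cc3s2)cc1I`) stands at < 10 nM. That entry is a limit of the assay and not a number. It is also the only anchor available, since (the limit of < 10 nM in this assay, at which 1 of the 2 values shown sits). Compound 2 (`Cc1cc(-c2nc3c(F)cccc3s2)ccc1N`) offers no comparison, as the entry for compound 2 reads no result reported. Within the data shown here, no measured step between two compounds is therefore available to guide the next one.

Compound 3 (`Cc1cc(-c2nc3ccc(F)cc3s2)ccc1N`) departs from compound 1 in a single place, with methyl in place of iodo on an aromatic carbon, ortho to an amino group and meta to a large group (methyl in place of iodo on an aromatic carbon). The rest of the core of compound 1 is kept unchanged.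

Among the measured compounds shown here, with no measured step to draw on, only a modest change is expected in this assay, with weaker inhibition of growth slightly more likely than stronger, and possibly none beyond the scatter. The estimated step that the limit leaves unreadable from compound 1 to compound 3 is expected to be small. Compound 3 is expected to give about 5 nM, with an estimated range from 1 nM to 30 nM.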

Compound 3, concentration for 50% growth inhibition: < 10 nM
Compound 3: only a limit was reported; the forecaster's own chance of this, stated with the estimate: 50%; the middle value lies beyond the limit too.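

In this assay compound 3 gives < 10 nM, which is a limit of the assay and not a number. Compound 1 also carries only a limit, so no step between compound 1 and compound 3 can be read: the limit of < 10 nM in this assay, at which 2 of the 3 values shown sit.

The compounds shown leave open whether methyl in place of iodo changes inhibition of growth at all in this assay.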